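A few compounds are considered here, and "the series" means these few. Any claim that something is new, unique, unknown or untested is made for them only; others in the source may bear on it.

Measured so far:
compound 1, `CSc1ncccc1OC[C@@H]1CCCN1C`: 559 nM
compound 2, `CN1CCC[C@H]1COc1cncc(C(F)(F)F)c1`: 1.83 nM

In an assay on membranes from brain for displacement of a labelled ligand from Neuronal acetylcholine receptor; alpha4/beta2 (Rattus norvegicus) (a higher number here means a weaker inhibitor, a lower number a stronger inhibitor), compound 2 gives the lowest of the two numbers, and compound 1 sits far above it, a gap well beyond the usual scatter of this kind of measurement. Compound 3, `CCCCCCc1cncc(OC[C@@H]2CCCN2C)c1`, has not yet been measured; it differs from compound 2 in one place: hexyl in place of trifluoromethyl on an aromatic carbon. Among the measured compounds shown here, no measured pair shows what such a swap does here, so the expectation rests on the change itself. A weakening beyond the scatter is expected, with a step estimated at a 27-fold higher number from compound 2 to compound 3 (1.44 log units; beyond the scatter). Compound 3 is therefore expected to give about 50 nM, between 8 nM and 300 nM.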

Compound 3, inhibition constant: 0.32 nM
Beside the measured number, compound 3's estimate is 160-fold (2.19 log units) above it; measured number below the stated range.
By their numbers in this assay, from the lowest: compound 3; then compound 2; then compound 1.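

On this aromatic carbon, two atoms from the ring nitrogen, swapping trifluoromethyl for hexyl in this assay gives a 5.7-fold lower number from compound 2 to compound 3 (0.76 log units; beyond the scatter) and so improves on an already low number. This position therefore accepts a chain of six carbons without losing strength at this receptor. The data give no explanation for the gain.

One chain length cannot show whether length itself matters here. A shorter propyl chain, a longer octyl chain, or a hexyl chain ending in an amine or a carboxylic acid would each test this further.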